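The compounds below may be only part of what the source reports. "The series", "measured", "known", "first", "only" and "open" are said of these compounds alone.

Compound 3 `O=S(=O)(Nc1ccc2oc(-c3ccccc3)nc2c1)c1cccs1` is known in an assay on isolated protein for inhibition of malate dehydrogenase, mitochondrial (Sus scrofa), with stated times of 45 min and 30 min (on this read-out lower numbers stand for stronger inhibition and higher numbers for weaker inhibition), only as a limit: compound 3 gives > 63000 nM. Compound 1 `O=S(=O)(Nc1ccc(-c2nc3ccccc3o2)cc1)c1cccs1` likewise reaches only a limit in this assay, > 63000 nM. Compound 2 `Cc1ccccc1S(=O)(=O)Nc1ccc(-c2nc3ccccc3o2)cc1` also stops at a limit, > 63000 nM. All three values sit at the limit of > 63000 nM in this assay, at which 3 of the 3 values shown sit, so the step that the two limits leave unreadable from compound 1 to compound 2 cannot be read from either end. Compound 4 `O=S(=O)(Nc1ccc2oc(-c3ccccc3)nc2c1)c1ccccc1F` differs from compound 3 by 2-fluorophenyl in place of thiophen-2-yl on a sulfonyl sulfur. Among the compounds with values here, the one measured step that resembles this change, a six-membered carbon ring in place of thiophen-2-yl on the sulfonyl sulfur, left both partners at the limit, so no shift beyond the scatter is expected here. Compound 4 is therefore estimated at 100000 nM, between 30000 nM and 300000 nM, an expected step that the limit leaves unreadable from compound 3 to compound 4 that most likely again ends as a limit.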

Compound 4, half-maximal inhibitory concentration: > 63000 nM
Compound 4: a limit, no number (the forecaster's own chance of this, stated with the estimate: 85%); the middle value lies beyond the limit too.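

Within the data shown here, compound 3 and compound 4 both end at a limit, so no step between them can be read: the limit of > 63000 nM in this assay, at which 4 of the 4 values shown sit. The compounds shown leave open how strongly any of them acts in this assay, and whether any group on the sulfonyl sulfur matters.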